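From Phenyl to 3-Hydroxyphenyl in Compound 3

This account rests on a few compounds, and the source may have more. Where it says the series, first, only, none or still open, it means among the compounds named here.

Among the compounds with values here, in a functional assay on A2780 cells (Homo sapiens) for antiproliferative activity, read by MTT assay, with a stated time of 48 h (a higher number here means a weaker inhibitor of growth, a lower number a stronger inhibitor of growth), compound 1 `COC(=O)N1N=C(c2ccccc2)CC1c1cc(OC)c(OC)c(OC)c1` gives 2770 nM, while compound 2 `CCOC(=O)N1N=C(c2ccccc2)CC1c1cc(OC)c(OC)c(OC)c1` gives 6720 nM, the higher of the two numbers so far. Compound 2 is therefore the weaker growth inhibitor of this pair, and it is the starting point here.

Compound 3 `CCOC(=O)N1N=C(c2cccc(O)c2)CC1c1cc(OC)c(OC)c(OC)c1` differs from compound 2 at one place: hydroxy in place of hydrogen on an aromatic carbon. This is hydroxy in place of hydrogen on an aromatic carbon, so phenyl becomes 3-hydroxyphenyl.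

Within the data shown here, only one measured step is available as a guide, a 2.4-fold higher number from compound 1 to compound 2 (0.38 log units; beyond the scatter). It is a modest step, and it lies on a saturated chain, not on the aromatic ring. Among the measured compounds shown here, no measured compound carries a hydroxy group, so this step offers only a rough sense of size and does not show a direction. A small change in this assay is therefore expected, leaning weakly towards a lower number, and possibly no real change at all. The estimate amounts to an expected 1.7-fold lower number from compound 2 to compound 3 (0.23 log units; within the scatter). For compound 3 the estimated value is 4000 nM, with an expected range of 900 nM to 15000 nM.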

Compound 3, concentration for 50% growth inhibition: 9750 nM
Estimate against measurement, compound 3: 2.4-fold (0.39 log units) below; measured number inside the range.
By their numbers in this assay, from the lowest: compound 1; then compounds 2 and 3 (each within the scatter of the next).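

In this assay the change from phenyl to 3-hydroxyphenyl gives a 1.5-fold higher number from compound 2 to compound 3 (0.16 log units; within the scatter) and so produces no real difference between this pair. Within the data shown here, this is the first look at the aromatic ring, and it shows that a hydroxy group, with its hydrogen-bond donor and acceptor, can stand at this place without moving the number outside the scatter, whereas the earlier change on the saturated chain gave a 2.4-fold higher number from compound 1 to compound 2 (0.38 log units; beyond the scatter) and did pass beyond it. No measurement is available that could explain why the hydroxy group leaves the number within the scatter.

From the compounds shown here alone, a single group at a single place says little about this ring as a whole, so it remains open whether an amine, a carboxylic acid or a fluorine atom at the same carbon would also leave the number within the scatter, or whether a hydroxy group on another carbon of the ring would do so. Going by these compounds, it is also open whether the same hydroxy group would give a similar result when added to compound 1, which has the shorter chain.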